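The source may hold more compounds than are shown below. What is called first, only, known or untested is meant among the compounds shown, and "the series" means these compounds.

Measured in an ADME assay on microsomes from liver (Homo sapiens) for metabolic stability, using NADPH, with a stated time of 60 min, in the presence of a further agent that is not named here; on this read-out higher numbers stand for fast clearance and lower numbers for slow clearance:
Compound 1 `O=C(O)COc1ccc([C@H]2CC[C@]3(CC2)OOC2(O3)C3CC4CC(C3)CC2C4)cc1Cl`: < 7 mL.min-1.g-1, a limit
Compound 2 `O=C(O)CN1CCC(Oc2ccc([C@H]3CC[C@]4(CC3)OOC3(O4)C4CC5CC(C4)CC3C5)cc2)CC1`: < 7 mL.min-1.g-1, a limit
Compound 3 `O=C(O)CCCCOc1ccc([C@H]2CC[C@]3(CC2)OOC2(O3)C3CC4CC(C3)CC2C4)cc1`: < 7 mL.min-1.g-1, a limit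

Compound 3 has only a limit and no number, and it shares this with the other two compounds: the limit of < 7 mL.min-1.g-1 in this assay, at which 3 of the 3 values shown sit. Compound 4 `O=C(O)CCCOc1ccc([C@H]2CC[C@]3(CC2)OOC2(O3)C3CC4CC(C3)CC2C4)cc1` has 3-carboxypropyl where compound 3 has 4-carboxybutyl, and the change is carboxy in place of carboxymethyl on a saturated chain carbon, three bonds along the chain from an oxygen on an aromatic ring. The nearest measured change is a step that the two limits leave unreadable from compound 2 to compound 3, so it provides no size to carry over. With every chain so far at that limit, no step beyond the scatter is expected in this assay. The expected step is a step that the limit leaves unreadable from compound 3 to compound 4. Compound 4 is estimated at 5 mL.min-1.g-1, within a range of 2.5 mL.min-1.g-1 to 10 mL.min-1.g-1.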

Compound 4, intrinsic clearance in microsomes: < 7 mL.min-1.g-1
Compound 4: a limit, no number (the forecaster's own chance of this, stated with the estimate: 85%); the middle value lies beyond the limit too.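

Neither the step from compound 3 to compound 4 nor that from compound 2 to compound 4 can be read, as all these results are limits: the limit of < 7 mL.min-1.g-1 in this assay, at which 4 of the 4 values shown sit.

The compounds shown leave open whether swapping these chains changes intrinsic clearance in microsomes at all.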